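The source may hold more compounds than are shown below. What is called first, only, known or untested is meant among the compounds shown, and "the series" means these compounds.

For the measured compounds named here, in an ADME assay on Vero cells (Chlorocebus sabaeus) for cytotoxicity, read by resazurin assay, with a stated time of 72 h (on this read-out higher numbers stand for weaker inhibition and lower numbers for stronger inhibition), compound 2 (`O=C(CCN1CCN(c2ccc(C(F)(F)F)cc2)CC1)c1ccc(F)c(F)c1`) gives 14000 nM, the lower of the two numbers so far, while compound 1 (`O=C(CCN1CCN(c2ccc(C(F)(F)F)cc2)CC1)c1ccc(F)c(Br)c1`) gives 66800 nM. Compound 3 (`O=C(CCN1CCN(c2ccc(C(F)(F)F)cc2)CC1)c1ccc(F)c(Cl)c1`) carries chloro in place of fluoro on an aromatic carbon of compound 2: chloro in place of fluoro on an aromatic carbon. Going by the values given here, the one measured step bearing on this is a 4.8-fold lower number from compound 1 to compound 2 (0.68 log units; beyond the scatter), with fluoro in place of bromo. The new swap runs back toward compound 1, so a higher number and a smaller step are expected in this assay. The expected step is a 2.3-fold higher number from compound 2 to compound 3 (0.36 log units; beyond the scatter). Compound 3 is estimated at 32000 nM, with a range from 15000 nM to 70000 nM.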

Compound 3, half-maximal inhibitory concentration: 74500 nM
Compound 3: middle estimate off by 2.3-fold (0.37 log units), on the low side; measured number above the stated range.
By their numbers in this assay, from the lowest: compound 2; then compounds 1 and 3 (each within the scatter of the next).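

In this assay chloro in place of fluoro gives a 5.3-fold higher number from compound 2 to compound 3 (0.73 log units; beyond the scatter) while chloro in place of bromo gives a 1.1-fold higher number from compound 1 to compound 3 (0.05 log units; within the scatter) so chloro and bromo cannot be told apart here. Among these three halogens on this aromatic carbon, fluoro alone stands apart, and chloro does not fall midway between fluoro and bromo.

Still open, as far as these compounds go, is how a group other than a halogen, such as methoxy, a nitrile or an amine, would read at this position. Nothing shown here gives a reason why fluoro differs from the other two halogens.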